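The source may report more compounds than this note shows. Statements on the series, on what has been measured and on what is new or still open speak of the compounds shown alone.

Series notes, shared core with a pendant aryl ring on a saturated ring carbon. Compound 1 `COc1cc(/C=C/C(=O)C2=C(/C=C/c3ccc(O)c(OC)c3)NC(=O)NC2c2ccccc2O)ccc1O` carries 2-hydroxyphenyl there; in a functional assay, with a stated time of 20 min, tested at 20 uM (a higher number here means a stronger effect of the compound at the concentration tested, a lower number a weaker effect), compound 1 gives 81%. Compound 2 `COc1cc(/C=C/C(=O)C2=C(/C=C/c3ccc(O)c(OC)c3)NC(=O)NC2c2c(Cl)cccc2Cl)ccc1O` carries 2,6-dichlorophenyl instead, and in this assay compound 2 gives 31.9%. Among the measured compounds shown here, compound 2 stands lowest of the two numbers so far; its nearest neighbour is compound 1, and the step of a number 49.1 percentage points lower from compound 1 to compound 2 (beyond the scatter). Compound 3 `COc1cc(/C=C/C(=O)C2=C(/C=C/c3ccc(O)c(OC)c3)NC(=O)NC2c2ccccc2Cl)ccc1O` differs from compound 2 by hydrogen in place of chloro on an aromatic carbon; read one bond further out, the change is 2,6-dichlorophenyl to 2-chlorophenyl. For the measured compounds named here, only the step from compound 1 to compound 2 bears on this, and it was large; compound 3 is neither compound 1 nor compound 2, keeping one chloro while shedding the other, so a partial return toward compound 1 in this assay is expected rather than a full one. The step from compound 2 to compound 3 is estimated as a number 18.1 percentage points higher from compound 2 to compound 3 (beyond the scatter), upward but uncertain. For compound 3 the expected activity in this assay is 50%, with a range from 25% to 75%.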

Compound 3, a percentage reported as activity, at one concentration (the size of the read-out at that concentration, not a potency): 46%
Compound 3: middle estimate off by 4 percentage points, on the high side; the measured number falls inside the stated range.
By their numbers in this assay, from the lowest: compound 2; then compound 3; then compound 1.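

In this assay, shedding one of the two chloro groups recovers only a small part of the lost activity: the change from 2,6-dichlorophenyl to 2-chlorophenyl gives a number 14.1 percentage points higher from compound 2 to compound 3 (beyond the scatter) and so moves the number upward, but not back to the level of the 2-hydroxyphenyl compound. The exchange of hydroxy for chloro on this aromatic carbon gives a number 35 percentage points lower from compound 1 to compound 3 (beyond the scatter) and is thus the larger part of the overall drop, which the earlier a number 49.1 percentage points lower from compound 1 to compound 2 (beyond the scatter) could not divide between the two chloro groups. No measurement at hand gives a reason for either step.

The compounds shown leave open how much of the large step belongs to the loss of hydroxy and how much to the arrival of chloro, a split that the plain phenyl group, or a methoxy or amino group on the same aromatic carbon, would help to settle. Also open, on these data alone, is whether a single chloro group on another carbon of this ring would give a similar number in this assay or a different one.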